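The source may hold more compounds than are shown below. What is called first, only, known or untested is meant among the compounds shown, and "the series" means these compounds.

Measured in a functional assay on U-373MG ATCC cells (Homo sapiens) for inhibition, read by MTT assay, with a stated time of 72 h; a lower number here means a stronger inhibitor, a higher number a weaker inhibitor:
Compound 1 `CC(C)NC(=S)NC1CC(C)(C)Oc2ccc(Cl)cc21`: 57000 nM
Compound 2 `CCNC(=S)NC1CC(C)(C)Oc2ccc(Cl)cc21`: 96000 nM
Compound 3 `CC1(C)CC(NC(=S)NCc2ccccc2)c2cc(Cl)ccc2O1`: 64000 nM

Compound 3 stands within the scatter of both other compounds, with a 1.1-fold higher number from compound 1 to compound 3 (0.05 log units; within the scatter) and a 1.5-fold lower number from compound 2 to compound 3 (0.18 log units; within the scatter). Compound 4 `CC1(C)CC(NC(=S)Nc2cccc(C#N)c2)c2cc(Cl)ccc2O1` has 3-cyanophenyl in place of benzyl on an amide-type nitrogen whose other neighbours are: thiocarbonyl carbon (3-cyanophenyl in place of benzyl on an amide-type nitrogen). The measured steps that bear on this change are the two substitutions at that nitrogen, and both stayed within the scatter. The third, a 1.7-fold higher number from compound 1 to compound 2 (0.23 log units; within the scatter), did too. Among the measured compounds shown here, none of the measured compounds carries a nitrile, so these steps are only a weak guide. The expected result in this assay is a 1.6-fold lower number from compound 3 to compound 4 (0.20 log units; within the scatter), which would be no change beyond the scatter. For compound 4 the estimated value is 40000 nM, with an expected range from 15000 nM to 90000 nM.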

Compound 4, half-maximal inhibitory concentration: 7000 nM
Beside the measured number, compound 4's estimate is 5.7-fold (0.76 log units) above it; the measured number lies below the stated range.
By their numbers in this assay, from the lowest: compound 4; then compounds 1, 3 and 2 (each within the scatter of the next).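

In this assay, isopropyl, ethyl and benzyl on the amide-type nitrogen had stayed within the scatter of one another, but 3-cyanophenyl there separates clearly from all three (a 9.1-fold lower number from compound 3 to compound 4 (0.96 log units; beyond the scatter); a 14-fold lower number from compound 2 to compound 4 (1.14 log units; beyond the scatter); an 8.1-fold lower number from compound 1 to compound 4 (0.91 log units; beyond the scatter)). Among the compounds shown here, this position can therefore shift the number beyond the scatter, and compound 4 is the only one of the four compounds that does so. Nothing available gives a reason for this step.

On these data alone, it remains open whether the nitrile or the phenyl ring carries the step; an unsubstituted phenyl on that nitrogen would separate the two. As far as these compounds go, whether a methoxy or trifluoromethyl group on that ring would do the same also remains open.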